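The source may report more compounds than this note shows. Statements on the series, on what has been measured and on what is new or still open speak of the compounds shown alone.

Of the compounds shown here, three have been measured in a functional assay on MIA PaCa-2 cells (Homo sapiens) for antiproliferative activity, read by MTT assay, with a stated time of 72 h; a higher number here means that more compound is needed for the effect, a lower number that less compound is needed. Compound 1 `Cc1nn(Cc2ccccc2)c(C)c1NC(=O)c1ccc(COc2ccccc2)cc1` gives 10000 nM in this assay. Compound 2 `Cc1nn(Cc2ccc(C(N)=O)cc2)c(C)c1NC(=O)c1ccc(COc2ccccc2)cc1` reaches only a limit of the assay, > 100000 nM, rather than a number. Compound 3 `CNC(=O)c1cccc(Cn2nc(C)c(NC(=O)c3ccc(COc4ccccc4C)cc3)c2C)c1` gives 2100 nM in this assay, and so stands lowest of the two numbers given, with compound 1 the nearest and clearly higher.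

For the measured compounds named here, only one pair of measured compounds differs in a single place: the change from compound 1 to compound 2 brings an at least 10-fold higher number from compound 1 to compound 2 (1.00 log units; beyond the scatter), a step that ends at the limit of > 100000 nM in this assay, at which 1 of the 3 values shown sits, so its true size is not known.

Compound 4 `CNC(=O)c1cccc(Cn2nc(C)c(NC(=O)c3ccc(COc4ccccc4C(F)(F)F)cc3)c2C)c1` differs from compound 3 by trifluoromethyl in place of methyl on an aromatic carbon. Going by the values given here, no measured step concerns a change at this place; the one measured step, carbamoyl in place of hydrogen, sits on a different ring of the shared core and says nothing about what trifluoromethyl in place of methyl will do. The expectation therefore rests on compound 3 alone, and a step of no more than the usual scatter is expected, a 1.4-fold lower number from compound 3 to compound 4 (0.15 log units; within the scatter). Compound 4 is thus estimated to give about 1500 nM in this assay, with a likely range from 500 nM to 5000 nM.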

Compound 4, half-maximal effective concentration: 10000 nM
Estimate against measurement, compound 4: 6.7-fold (0.82 log units) below; measured number above the stated range.
By their numbers in this assay, from the lowest: compound 3; then compounds 1 and 4 (each within the scatter of the next). At a limit, above all of these: compound 2.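

In this assay, this place is not indifferent to the change: trifluoromethyl in place of methyl, on an aromatic carbon ortho to a large group, gives a 4.8-fold higher number from compound 3 to compound 4 (0.68 log units; beyond the scatter). For the compounds shown here, the only earlier step put a carbamoyl group at a different part of the shared core, so this pair gives the first reading at this place, and here the exchange of one small group for another means that more compound is needed for the effect. The measurements shown include nothing that explains why this exchange moves the number in this direction.

Going by these compounds, with only methyl and trifluoromethyl compared here, a single pair gives a direction for this one exchange and no trend across groups, so it remains open whether a chlorine atom, a methoxy group or a longer chain such as ethyl at this place would give a number nearer to that of compound 3 or that of compound 4. On these data alone, it is also open whether the same exchange would bring a step of similar size if the other end of the molecule were changed.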